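Dropping One Trifluoromethyl From a Diaryl Urea

This account rests on a few compounds, and the source may have more. Where it says the series, first, only, none or still open, it means among the compounds named here.

compound 1 `O=C(Nc1cccc(-n2cc(-c3ccncc3)c(-c3cc(O)cc(Cl)c3)n2)c1)Nc1ccc(Cl)c(C(F)(F)F)c1`: 104%
compound 2 `COc1cc(Cl)cc(-c2nn(-c3cccc(NC(=O)Nc4cc(C(F)(F)F)cc(C(F)(F)F)c4)c3)cc2-c2ccncc2)c1`: 102%

In a functional assay on HCT-116 cells (Homo sapiens) for inhibition, read by sulforhodamine B assay, with a stated time of 48 h, tested at 0.01 uM (on this read-out higher numbers stand for a weaker effect at the one concentration tested and lower numbers for a stronger effect), compound 1 gives 104% and compound 2 gives 102%. The two numbers sit within the scatter of each other, so neither compound can be set apart, and both read as little inhibition at this concentration. Compound 3 `COc1cc(Cl)cc(-c2nn(-c3cccc(NC(=O)Nc4cccc(C(F)(F)F)c4)c3)cc2-c2ccncc2)c1` is the untested partner of compound 2; it differs by hydrogen in place of trifluoromethyl on an aromatic carbon. For the measured compounds named here, with no measured step to lean on and both known values near full activity, the step from compound 2 to compound 3 is expected to stay within the scatter, in either direction, as a number 1 percentage points lower from compound 2 to compound 3 (within the scatter). Compound 3 is therefore estimated at 101%, within 90% to 112%.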

Compound 3, a percentage reported as activity, at one concentration (the size of the read-out at that concentration, not a potency): 101%
The estimate for compound 3 equals the measured number at the digits printed, within the range that was stated.
By their numbers in this assay, from the lowest: compounds 3, 2 and 1 (each within the scatter of the next).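

Hydrogen in place of trifluoromethyl on this aromatic carbon gives a number 1 percentage points lower from compound 2 to compound 3 (within the scatter) in this assay and so leaves no readable mark at the one concentration tested. This first one-place step shows that compound 2, with its second trifluoromethyl, and compound 3, without it, cannot be told apart here. No measured evidence bears on why this is so.

Both compounds show little inhibition at this concentration, so this result cannot show whether the position matters at stronger effect. Going by these compounds, how an amine or a carboxylic acid on this carbon would read remains open.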